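Shortening the hydroxamate chain in an acrylamide-triazole series

This account rests on a few compounds, and the source may have more. Where it says the series, first, only, none or still open, it means among the compounds named here.

Among the compounds with values here, compound 1 `C=CC(=O)Nc1cc2c(Nc3cccc(Cl)c3F)ncnc2cc1OCc1cn(CCCCC(=O)NO)nn1` is one of two compounds measured in a functional assay on A549 cells (Homo sapiens) for antiproliferative activity, read by MTT assay, with a stated time of 72 h; a higher number here means a weaker inhibitor, a lower number a stronger inhibitor. For compound 1 the result is only a limit of the assay, > 50000 nM. Compound 2 `C=CC(=O)Nc1cc2c(Nc3ccc(OCc4cccc(F)c4)c(Cl)c3)ncnc2cc1OCc1cn(CCCC(=O)NO)nn1` likewise returns only a limit in this assay, > 50000 nM. Both results sit at the limit of > 50000 nM in this assay, at which 2 of the 2 values shown sit, so compound 2 cannot be ranked against compound 1 on these numbers. Compound 3 `C=CC(=O)Nc1cc2c(Nc3ccc(OCc4cccc(F)c4)c(Cl)c3)ncnc2cc1OCc1cn(CCC(=O)NO)nn1` differs from compound 2 by hydroxycarbamoyl in place of (hydroxycarbamoyl)methyl on a saturated chain carbon, two bonds along the chain from an aromatic nitrogen. Within the data shown here, with no step between measured compounds to go by, the change is expected to carry a step that the limit leaves unreadable from compound 2 to compound 3, nothing beyond the scatter in either direction. Compound 3 is therefore estimated at 60000 nM, within 20000 nM to 200000 nM, and is most likely to be reported again as a limit.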

Compound 3, half-maximal inhibitory concentration: > 50000 nM
Compound 3 ended at the assay's limit; the forecaster's own chance of this, stated with the estimate: 85%; the middle value is on the limit's open side.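

Compound 2 and compound 3 both end at a limit of the assay, so no step between them can be read: the limit of > 50000 nM in this assay, at which 3 of the 3 values shown sit.

The compounds shown leave open whether 2-(hydroxycarbamoyl)ethyl in place of 3-(hydroxycarbamoyl)propyl changes antiproliferative activity at all.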